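Switching the aryl group on the imine of compound 1

This account rests on a few compounds, and the source may have more. Where it says the series, first, only, none or still open, it means among the compounds named here.

Measured so far:
compound 1, `Cc1ccccc1/N=C1\NC(=O)/C(=C\c2ccc(N(C)C)cc2)S1`: 540 nM
compound 2, `COc1ccc(N=C2NC(=O)/C(=C\c3ccc(N(C)C)cc3)S2)cc1`: 1600 nM
compound 3, `CC(=O)Nc1ccc(/C=C2/S/C(=N/c3cccc(Cl)c3)NC2=O)cc1`: 1250 nM

Of the compounds shown here, three built on one shared core have been tested in a functional assay on NCI-H460 cells (Homo sapiens) for antiproliferative activity; on this read-out higher numbers stand for weaker inhibition and lower numbers for stronger inhibition. Compound 1 stands lowest of the three, and thus strongest; compound 3 sits a step above it that lies beyond the scatter, and compound 2 sits furthest away, also beyond the scatter. Compound 3 differs from compound 1 in more than one place, so its gap to compound 1 cannot be tied to a single change.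

The next compound, compound 4 with the structure `CN(C)c1ccc(/C=C2/S/C(=N/c3ccc(Cl)cc3)NC2=O)cc1`, differs from compound 1 in one place only: 4-chlorophenyl in place of 2-methylphenyl on a double-bonded nitrogen. Among the measured compounds shown here, no pair of measured compounds isolates this exact exchange, so there is no measured step to lean on. For the measured compounds named here, compound 2, which carries a different group on the same nitrogen, gives 1600 nM, and this is the only hint that a change at this position can move this assay upward. The expected step from compound 1 to compound 4, a 1.7-fold higher number from compound 1 to compound 4 (0.22 log units; within the scatter), is a modest rise, not clearly beyond the scatter. Compound 4 is therefore estimated at 900 nM in this assay, within a range from 400 nM to 2500 nM.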

Compound 4, half-maximal inhibitory concentration: 2930 nM
Estimate against measurement, compound 4: 3.3-fold (0.51 log units) below; the whole stated range lies below it.
By their numbers in this assay, from the lowest: compound 1; then compounds 3, 2 and 4 (each within the scatter of the next, the first and the last beyond it).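

The exchange of 2-methylphenyl for 4-chlorophenyl on a double-bonded nitrogen gives the first step measured at this position in this assay, and it is a clear one: a 5.4-fold higher number from compound 1 to compound 4 (0.73 log units; beyond the scatter). The two groups match in heavy atoms, each has one six-membered aromatic ring of carbon only, and neither has any hydrogen-bond donors or acceptors, yet the number still moves beyond the scatter, so this position responds to a change that leaves all of these counts the same. Nothing available gives a measured reason for the size of this step, and it stands here as an observation only.

This single exchange removes the methyl group and brings in the chlorine at once, so the compounds shown cannot tell how much of the step belongs to the loss of one and how much to the arrival of the other. Also open, from the compounds shown here alone, is how the shared core would fare in this assay with an unsubstituted phenyl on this nitrogen, which would separate those two parts, or with a non-aromatic group such as cyclohexyl in its place.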